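Moving the hydroxyl on a shared pyridine-free core

The source may report more compounds than this note shows. Statements on the series, on what has been measured and on what is new or still open speak of the compounds shown alone.

Compound 1 `Oc1ccc(-c2cc(-c3ccccc3)nc(-c3ccccc3Cl)c2)cc1`: 13.6%
Compound 2 `Oc1ccc(-c2cc(-c3ccco3)nc(-c3ccccc3Cl)c2)cc1`: 3.9%

In an assay on isolated protein for inhibition of DNA topoisomerase 1 (Homo sapiens), with a stated time of 30 min, tested at 100 uM (a higher number here means a stronger effect of the compound at the concentration tested, a lower number a weaker effect), compound 1 gives the highest of the two numbers, though the step of a number 9.7 percentage points lower from compound 1 to compound 2 (within the scatter) is within the scatter. Compound 3 `Oc1cccc(-c2cc(-c3ccccc3)nc(-c3ccccc3Cl)c2)c1` differs from compound 1 by 3-hydroxyphenyl in place of 4-hydroxyphenyl on an aromatic carbon. Going by the values given here, no measured step touches the hydroxyphenyl group, so nothing known bears directly on this change; the only step, from compound 1 to compound 2, was within the scatter. A step of no size beyond the scatter is therefore expected, giving a number 1.6 percentage points lower from compound 1 to compound 3 (within the scatter). Compound 3 is estimated at 12%, between 0% and 28%.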

Compound 3, a percentage reported as inhibition, at one concentration (the size of the read-out at that concentration, not a potency): 3.2%
The estimate for compound 3 lay 8.8 percentage points above the measured number; the range from low to high includes it.
By their numbers in this assay, from the lowest: compounds 3, 2 and 1 (each within the scatter of the next, the first and the last beyond it).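

Moving the hydroxyl, with 3-hydroxyphenyl taking the place of 4-hydroxyphenyl opposite the ring nitrogen, gives a number 10.4 percentage points lower from compound 1 to compound 3 (beyond the scatter) in this assay at this position. Going by these compounds alone, this is the first step here beyond the scatter, and since the two compounds have the same atoms joined differently, where the hydroxyl sits matters, if only modestly. No evidence on hand explains this step.

As far as these compounds go, whether an amine or a methoxy group in place of the hydroxyl would change the number remains open. So does whether the same move would have a similar effect on compound 2, which carries furan-2-yl.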